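This account rests on a few compounds, and the source may have more. Where it says the series, first, only, none or still open, it means among the compounds named here.

Compound 1 `Clc1ccc(-c2cc(-c3ccsc3)nc(-c3ccco3)c2)o1` is the starting point of this account. In a functional assay on K562 cells (Homo sapiens) for cytotoxicity, in the presence of a further agent that is not named here (on this read-out lower numbers stand for stronger inhibition and higher numbers for weaker inhibition), compound 1 gives 22400 nM, nominally the highest of the three numbers in hand, yet within the scatter of both companions: compound 2 `Clc1cccc(-c2cc(-c3ccc(Cl)o3)cc(-c3cccs3)n2)c1` gives 19800 nM and compound 3 `Cc1ccc(-c2cc(-c3ccc(Cl)o3)cc(-c3cccs3)n2)cc1` gives 21500 nM. Within the data shown here, the one recorded step, a 1.1-fold higher number from compound 2 to compound 3 (0.04 log units; within the scatter), exchanges one aryl group for another on the shared core and leaves the read-out essentially where it was. Compound 4 `Clc1ccc(-c2cc(-c3ccsc3)nc(-c3ccccn3)c2)o1` carries pyridin-2-yl in place of furan-2-yl on an aromatic carbon. Among the measured compounds shown here, no measured step concerns this exact exchange; the sole step on record, an aryl swap, stayed within the scatter, so no movement beyond the scatter is expected in this assay in either direction. Compound 4 is therefore estimated at 22000 nM, within 8000 nM to 60000 nM, meaning an expected step of a 1.0-fold lower number from compound 1 to compound 4 (0.01 log units; within the scatter).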

Compound 4, half-maximal inhibitory concentration: 21900 nM
Estimate against measurement, compound 4: 1.0-fold (0.00 log units) above; the measured number falls inside the stated range.
By their numbers in this assay, from the lowest: compounds 2, 3, 4 and 1 (each within the scatter of the next).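

In this assay, among these compounds, replacing furan-2-yl with pyridin-2-yl on the aromatic carbon next to the ring nitrogen gives a first step at this position (a 1.0-fold lower number from compound 1 to compound 4 (0.01 log units; within the scatter)). A five-membered aromatic ring thus gives way to a six-membered one with no change beyond the scatter. No evidence is available to explain this result.

On these data alone, compound 1 and compound 4 both carry an aromatic ring here, so it remains open whether an amine, a carboxylic acid or a longer alkyl chain at this place would move the number beyond the scatter.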